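Removing a Methyl from a Ring Amine: Expected Lipophilicity

A few compounds are considered here, and "the series" means these few. Any claim that something is new, unique, unknown or untested is made for them only; others in the source may bear on it.

The three measured compounds were all tested in a physicochemical assay for lipophilicity, measured as octanol-water partition, at pH 7.4; on this read-out lower numbers stand for lower lipophilicity and higher numbers for higher lipophilicity:

Compound 1, `Cc1ccc2[nH]c(C(=O)N[C@H]3CN(S(=O)(=O)c4ccccc4)C[C@@H]3C(=O)NCCN(C)C)cc2c1`, gives 2.1.
Compound 2, `Cc1ccc2[nH]c(C(=O)N[C@H]3CN(S(=O)(=O)c4ccccc4)C[C@@H]3C(=O)NC[C@H]3CCCN3C)cc2c1`, gives 2.3.
Compound 3, `Cc1ccc2[nH]c(C(=O)N[C@H]3CN(S(=O)(=O)c4ccccc4)C[C@@H]3C(=O)N[C@H]3CCCN(C)C3)cc2c1`, gives 2.7.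

Compound 3 stands highest of the three numbers shown: a number 0.60 log units higher from compound 1 to compound 3 (beyond the scatter), and a number 0.40 log units higher from compound 2 to compound 3 (beyond the scatter), both beyond the scatter. Between the other two, a number 0.20 log units higher from compound 1 to compound 2 (within the scatter).

Compound 4 is `Cc1ccc2[nH]c(C(=O)N[C@H]3CN(S(=O)(=O)c4ccccc4)C[C@@H]3C(=O)N[C@H]3CCCNC3)cc2c1`. The change from compound 3 is this: hydrogen in place of methyl on an amine nitrogen in a ring

Among the measured compounds shown here, none of the measured steps makes a change of this kind. Each of them exchanges one complete amine-bearing group for another, so none shows what happens when a methyl alone leaves an amine nitrogen in a ring while the rest of the molecule is kept. The expectation therefore rests only on the size of the change, one carbon lost and nothing added. A modest decrease is estimated, a number 0.40 log units lower from compound 3 to compound 4 (beyond the scatter), small enough that it may not clearly exceed the scatter. Compound 4 is expected to give 2.3, with a range from 1.8 to 2.8.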

Compound 4, distribution coefficient: 1.3
The estimate for compound 4 lay 1.00 log units above the measured number, and the stated range ends above it.
By their numbers in this assay, from the lowest: compound 4; then compounds 1 and 2 (each within the scatter of the next); then compound 3.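

In this assay, taking the methyl off the amine nitrogen of the ring while leaving the rest of the molecule untouched produces a large step, a number 1.40 log units lower from compound 3 to compound 4 (beyond the scatter), larger than any step seen when whole amine-bearing groups were exchanged. The order of the side chains on the amide-type nitrogen also reverses at this position: 1-methylpiperidin-3-yl stood highest, but piperidin-3-yl now stands lowest, with a number 1.00 log units lower from compound 2 to compound 4 (beyond the scatter) and a number 0.80 log units lower from compound 1 to compound 4 (beyond the scatter), so a single carbon on this ring nitrogen outweighs the differences among the three earlier groups. Among the compounds shown here, nothing available explains why the loss of this one methyl moves the number so far.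

As far as these compounds go, it remains open whether other groups on the same ring nitrogen, such as an ethyl or an acetyl, would bring the number back toward that of compound 3, which gives 2.7, or take it elsewhere. From the compounds shown here alone, it is also open whether removing a methyl from the (1-methylpyrrolidin-2-yl)methyl group of compound 2 or from the 2-(dimethylamino)ethyl group of compound 1 would produce a step of similar size, or whether this drop belongs to the piperidine-bearing group alone.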